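Replacing pyrrolidin-1-yl with dimethylamino on the shared core

This account rests on a few compounds, and the source may have more. Where it says the series, first, only, none or still open, it means among the compounds named here.

Measured so far in an ADME assay on L6 cells (Rattus norvegicus) for cytotoxicity; on this read-out higher numbers stand for weaker inhibition and lower numbers for stronger inhibition:
compound 1 `CCN1CCN(CCN2CCC3(N4CCCC4)CC(c4ccccc4)C2C(c2ccccc2)C3)CC1` gives 53600 nM
compound 2 `CN1CCN(CCC(=O)N2CCC3(N4CCCC4)CC(c4ccccc4)C2C(c2ccccc2)C3)CC1` gives 75400 nM

Among the measured compounds shown here, compound 1 has only one measured neighbour and stands within the scatter of it. That single step, a 1.4-fold higher number from compound 1 to compound 2 (0.15 log units; within the scatter), concerns the group on an amine nitrogen in a ring, so it bears only loosely on the next change. For the measured compounds named here, compound 3 `CCN1CCN(CCN2CCC3(N(C)C)CC(c4ccccc4)C2C(c2ccccc2)C3)CC1` has dimethylamino in place of pyrrolidin-1-yl on a saturated ring carbon, (dimethylamino in place of pyrrolidin-1-yl on a saturated ring carbon), and no measured step covers that place. No shift beyond the scatter is expected, and the estimated step is a 1.1-fold lower number from compound 1 to compound 3 (0.03 log units; within the scatter) in size. Compound 3 is estimated at 50000 nM, with an expected range from 20000 nM to 110000 nM.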

Compound 3, half-maximal inhibitory concentration: 58000 nM
Estimate against measurement, compound 3: 1.2-fold (0.06 log units) below, and the stated range covers the measured number.
By their numbers in this assay, from the lowest: compounds 1, 3 and 2 (each within the scatter of the next).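

In this assay, dimethylamino in place of pyrrolidin-1-yl on a saturated ring carbon gives a 1.1-fold higher number from compound 1 to compound 3 (0.03 log units; within the scatter) and so leaves the two compounds indistinguishable. Among the compounds shown here, this is the first reading at this position, and on this one pair, opening the ring and losing heavy atoms there has no effect beyond the scatter. No evidence available here explains this result. From the compounds shown here alone, a primary amine, a piperidine ring or a morpholine ring on the same carbon remains open. So does whether dimethylamino reads the same alongside the (2-(4-methylpiperazin-1-yl)ethyl)carbonyl group of compound 2.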